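A few compounds are considered here, and "the series" means these few. Any claim that something is new, unique, unknown or untested is made for them only; others in the source may bear on it.

Among the measured compounds shown here, in an assay on membranes from brain for displacement of a labelled ligand from adenosine receptor A1 (Rattus norvegicus) (a higher number here means a weaker inhibitor, a lower number a stronger inhibitor), compound 3 `COc1ccc(-c2nc3ccccn3c2NC2CCCCC2)cc1` gives 7610 nM, the only true number among the three measured compounds. For compound 1 `O=[N+]([O-])c1ccc(-c2nc3ccccn3c2NC2CCCCC2)cc1` the assay reports only a limit, > 100000 nM. For compound 2 `Fc1ccc(-c2nc3ccccn3c2NC2CCCCC2)cc1` the result is likewise a limit, > 100000 nM. Two steps are therefore readable: an at least 13-fold lower number from compound 1 to compound 3 (1.11 log units; beyond the scatter) and an at least 13-fold lower number from compound 2 to compound 3 (1.11 log units; beyond the scatter). The third, a step that the two limits leave unreadable from compound 1 to compound 2, cannot be sized, owing to the limit of > 100000 nM in this assay, at which 2 of the 3 values shown sit.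

Compound 4 `Oc1ccc(-c2nc3ccccn3c2NC2CCCCC2)cc1` differs from compound 3 by hydrogen in place of methyl on an oxygen on an aromatic ring. For the measured compounds named here, none of the measured steps touches this place: each of them exchanges one whole group on the aromatic carbon for another, whereas here the oxygen on the ring stays and only the methyl on that oxygen gives way to hydrogen. The measured steps thus give no direct guide for this change, and the expected step is a small one, within the usual scatter and in no firm direction, a 1.1-fold higher number from compound 3 to compound 4 (0.02 log units; within the scatter). Compound 4 is accordingly estimated at 8000 nM, with a range from 2000 nM to 32000 nM.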

Compound 4, inhibition constant: 5530 nM
The estimate for compound 4 lay 1.4-fold (0.16 log units) above the measured number; the measured number falls inside the stated range.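

In this assay the methyl on the oxygen can give way to hydrogen with no change beyond the scatter, the step being a 1.4-fold lower number from compound 3 to compound 4 (0.14 log units; within the scatter), so methoxy and hydroxy read alike at this place. Hydroxy, like methoxy, stands clearly apart from fluoro and nitro on the aromatic carbon, with an at least 18-fold lower number from compound 2 to compound 4 (1.25 log units; beyond the scatter) and an at least 18-fold lower number from compound 1 to compound 4 (1.25 log units; beyond the scatter) as the two steps. Both of these steps are open-ended, because compound 1 and compound 2 each give a limit of the assay and not a true number: the limit of > 100000 nM in this assay, at which 2 of the 4 values shown sit.

On these data alone, whether a group without oxygen on this aromatic carbon, such as an amine or a plain methyl, would read like methoxy and hydroxy stays open. So does whether a longer chain on the oxygen, such as ethoxy or propoxy, would leave the number unchanged.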